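The source may report more compounds than this note shows. Statements on the series, on what has been measured and on what is new or still open speak of the compounds shown alone.

Of the compounds shown here, two have been measured so far in a functional assay on COLO 205 cells (Homo sapiens) for inhibition, read by sulforhodamine B assay, tested at 100 uM; on this read-out lower numbers stand for less inhibition of growth and higher numbers for more inhibition of growth at the one concentration tested. Compound 1, `CC(=O)N1N=C(c2ccc(OCc3cn(Cc4ccc([N+](=O)[O-])cc4)nn3)cc2)CC1c1ccccc1`, gives 55% in this assay. Compound 2, `COc1cc(C2CC(c3ccc([N+](=O)[O-])cc3)=NN2C(C)=O)ccc1OCc1cn(Cc2ccc([N+](=O)[O-])cc2)nn1`, gives 85% and stands highest of the two numbers; compound 1 sits well below it, and the gap between them lies beyond the usual scatter of repeated measurements, so the two are genuinely distinct on this read-out.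

Compound 3, `COc1cc(C2CC(c3ccc(Br)cc3)=NN2C(C)=O)ccc1OCc1cn(Cc2ccc([N+](=O)[O-])cc2)nn1`, has not yet been measured. It differs from compound 2 in a single place: bromo in place of nitro on an aromatic carbon. For the measured compounds named here, no measured pair in this small set shows the same change, so its effect cannot be read off directly and has to be estimated from the two numbers alone.

The expectation is that the change costs some growth inhibition, but not all of the margin that compound 2 holds over compound 1. The expected step is a number 15 percentage points lower from compound 2 to compound 3 (beyond the scatter), a moderate fall that is only somewhat beyond the scatter. For compound 3 the estimated value in this assay is 70%, with a range from 45% to 90%.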

Compound 3, percent growth inhibition at one concentration: 47%
Compound 3: middle estimate off by 23 percentage points, on the high side; the measured number falls inside the stated range.
By their numbers in this assay, from the lowest: compounds 3 and 1 (each within the scatter of the next); then compound 2.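

In this assay, for the compounds shown here, the step from 4-nitrophenyl to 4-bromophenyl brings a number 38 percentage points lower from compound 2 to compound 3 (beyond the scatter) and gives the first direct reading at this position, on an aromatic carbon para to a large group. It shows that growth inhibition here depends strongly on what this carbon carries, at least between these two groups: a nitro group of three heavy atoms with two hydrogen-bond acceptors leaves, and a single bromine atom with none enters. No measurement at hand gives a reason for this fall.

Going by these compounds, with only nitro and bromo compared at this carbon, it remains open whether nitro is specifically favourable or bromo specifically unfavourable, and an amine or a carboxylic acid at the same place would help separate the two. A single pair also cannot show whether the same bromo for nitro change would have a similar effect elsewhere on these molecules or on a compound with a different substitution pattern.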